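Chlorodihydropyran Side Chains: Dibromoalkene to Terminal Alkyne

This account rests on a few compounds, and the source may have more. Where it says the series, first, only, none or still open, it means among the compounds named here.

Compound 1, `CC(C)CC1C=C(Cl)CCO1`: in a functional assay on WiDr cells (Homo sapiens) for antiproliferative activity (a higher number here means a weaker inhibitor of growth, a lower number a stronger inhibitor of growth), compound 1 gives only a limit, > 100000 nM.
Compound 2, `ClC1=CC(CCC=C(Br)Br)OCC1`: in this assay compound 2 gives 23000 nM.

Compound 2 holds the only numerical result here; the other measurement is a limit (the limit of > 100000 nM in this assay, at which 1 of the 2 values shown sits). Compound 3, `C#CCCC1C=C(Cl)CCO1`, carries ethynyl in place of 2,2-dibromoethenyl on a saturated chain carbon, two bonds along the chain from a saturated ring carbon. Compound 1 shows that a plain alkyl chain on the shared core registers nothing, so the loss of both bromines in compound 3 is expected to weaken growth inhibition moderately, with a fair chance that only a limit is reported. Compound 3 is therefore estimated at 60000 nM (range 20000 nM to 150000 nM), a step of a 2.6-fold higher number from compound 2 to compound 3 (0.42 log units; beyond the scatter).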

Compound 3, concentration for 50% growth inhibition: > 100000 nM
Compound 3 gave a limit, no number; the forecaster's own chance of this, stated with the estimate: 40%; middle value at least 1.6-fold (0.22 log units) from the limit.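

In this assay compound 3 gives > 100000 nM, a limit and not a number. Ethynyl in place of 2,2-dibromoethenyl gives an at least 4.3-fold higher number from compound 2 to compound 3 (0.63 log units; beyond the scatter), so at this position the terminal alkyne does not keep the growth inhibition seen with the dibromoalkene. The step between compound 1 and compound 3 cannot be read, and most of the set now rests on a limit: the limit of > 100000 nM in this assay, at which 2 of the 3 values shown sit.

Still open is whether the bromines or the double bond matter more, as no compound shown has one without the other. A 2,2-dichloroethenyl group or a longer chain ending in 2,2-dibromoethenyl would extend the comparison.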